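This account rests on a few compounds, and the source may have more. Where it says the series, first, only, none or still open, it means among the compounds named here.

Compounds measured in a functional assay on SH-SY5Y cells (Homo sapiens) for cytotoxicity, read by MTT assay, with stated times of 8 h, 30 min and 12 h, tested at 0.05 uM; a lower number here means a weaker effect, a higher number a stronger effect of the compound at the concentration tested:

Compound 1, `N=C(NCc1ccccc1)[C@@H]1CCC(=O)N1Cc1ccc(F)cc1`, gives 13.3%.
Compound 2, `N=C(NCc1ccc(O)cc1)[C@@H]1CCC(=O)N1Cc1ccc(F)cc1`, gives 35.2%.
Compound 3, `COc1ccc(CNC(=N)[C@@H]2CCC(=O)N2Cc2ccc(F)cc2)cc1`, gives 15.8%.

Compound 2 stands highest of the three in this assay, and both of its neighbours lie beyond the scatter below it: compound 3 at a number 19.4 percentage points lower from compound 2 to compound 3 (beyond the scatter) and compound 1 at a number 21.9 percentage points higher from compound 1 to compound 2 (beyond the scatter). The two steps measured so far both sit on the benzyl ring bearing the hydroxy, namely a number 21.9 percentage points higher from compound 1 to compound 2 (beyond the scatter) and a number 2.5 percentage points higher from compound 1 to compound 3 (within the scatter), together with a number 19.4 percentage points lower from compound 2 to compound 3 (beyond the scatter).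

Compound 4, `Cc1ccc(CN2C(=O)CC[C@H]2C(=N)NCc2ccc(O)cc2)cc1`, has not yet been measured. It differs from compound 2 at the other ring: methyl in place of fluoro on an aromatic carbon. For the measured compounds named here, none of the measured steps touches this ring, so the data give no direct guide to the size or direction of the change in this assay. With nothing pointing either way, the expectation is a step near zero, within the scatter: the estimated step is a number 0.2 percentage points lower from compound 2 to compound 4 (within the scatter). Compound 4 is therefore expected to give about 35% in this assay, with a range from 20% to 50%.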

Compound 4, a percentage reported as activity, at one concentration (the size of the read-out at that concentration, not a potency): 20.5%
Compound 4: middle estimate off by 14.5 percentage points, on the high side; low and high end bracket the measured number.
By their numbers in this assay, from the lowest: compounds 1, 3 and 4 (each within the scatter of the next); then compound 2.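

For the compounds shown here, for the first time the ring at the other end of the molecule is varied, and it turns out not to be silent: methyl in place of fluoro, para to a large group, gives a number 14.7 percentage points lower from compound 2 to compound 4 (beyond the scatter) in this assay. The exchanged groups match in heavy-atom count and in hydrogen-bond donors and acceptors, so a change this small in those counts is still enough to move the reading, and compound 2 now lies beyond the scatter above its neighbours at both ends, since removing the methyl-free hydroxy gives a number 19.4 percentage points lower from compound 2 to compound 3 (beyond the scatter) on the benzyl side. No measurement at hand explains why the 4-methylbenzyl compound reads lower than the 4-fluorobenzyl one.

With only fluoro and methyl shown at this position, it remains open whether fluoro raises the reading or methyl lowers it, and chloro, methoxy or an amine there could help to separate the two. On these data alone, it is also open whether the same exchange would give a similar step where the hydroxy is absent, as in compound 1, or is capped as the methoxy of compound 3.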